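Neopentyl amine in place of 4-nitrobenzyl amine

The source may report more compounds than this note shows. Statements on the series, on what has been measured and on what is new or still open speak of the compounds shown alone.

Of the compounds shown here, three have been measured in an in vitro assay on CHOK cells for displacement of a labelled ligand from growth hormone secretagogue receptor type 1 (Homo sapiens); a higher number here means a weaker inhibitor, a lower number a stronger inhibitor. Compound 1 `CCc1nc(N)nc(N)c1-c1ccc(NCc2ccc([N+](=O)[O-])cc2)cc1` gives 11 nM, compound 2 `Nc1nc(N)c(-c2ccc(NCc3ccc([N+](=O)[O-])cc3)cc2)c(COCc2ccccc2)n1` gives 0.2 nM, and compound 3 `Nc1nc(N)c(-c2ccc(NCc3cc(F)c(S(=O)(=O)C(F)(F)F)c(F)c3)cc2)c(COCc2ccccc2)n1` gives 1 nM. Compound 2 holds the lowest number of the three; the nearest is compound 3, the furthest compound 1. For the measured compounds named here, the one step between neighbours that differ in a single place, a 55-fold lower number from compound 1 to compound 2 (1.74 log units; beyond the scatter), concerns the benzyloxy group that compounds 2 and 3 share.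

Compound 4 `CC(C)(C)CNc1ccc(-c2c(N)nc(N)nc2COCc2ccccc2)cc1` keeps that benzyloxy group and changes the other end: tert-butyl in place of 4-nitrophenyl on a saturated chain carbon bound to a nitrogen on an aromatic ring. Going by the values given here, no measured step bears on this position. The pair of compound 2 and compound 3 shows only what two different benzyl groups on the amine give: compound 2 gives 0.2 nM and compound 3 gives 1 nM; the aromatic ring is kept in both, whereas in compound 4 it is gone.

With nothing to anchor the change, the estimate leans on the loss of the ring and the nitro group and expects a higher number, a 25-fold higher number from compound 2 to compound 4 (1.40 log units; beyond the scatter), beyond the scatter but not as large as the measured step. Compound 4 is therefore estimated at 5 nM, within 1 nM to 30 nM.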

Compound 4, half-maximal inhibitory concentration: 67 nM
For compound 4 the middle estimate is 13-fold (1.13 log units) below the measured one, outside the stated range (above it).
By their numbers in this assay, from the lowest: compound 2; then compound 3; then compound 1; then compound 4.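

In this assay, for the compounds shown here, the step of a 340-fold higher number from compound 2 to compound 4 (2.53 log units; beyond the scatter) is large and is the first measured change at this position, on a saturated chain carbon bound to a nitrogen on an aromatic ring: the position does not accept tert-butyl as an equal replacement for 4-nitrophenyl. Compound 4 retains the benzyloxy group linked to the step of a 55-fold lower number from compound 1 to compound 2 (1.74 log units; beyond the scatter) and still has a high number, so that group alone does not secure a low value when the neopentyl amine replaces the 4-nitrobenzyl amine. Nothing at hand gives a measured cause for the step from 4-nitrophenyl to tert-butyl.

The change removes the aromatic ring and the nitro group together, so the compounds shown leave open which of the two matters; a plain benzyl amine or a cyclohexylmethyl amine on the same core would begin to separate them. Also open, as far as these compounds go, is how this position responds to a longer unbranched chain, such as n-pentyl, or to a chain ending in a carboxylic acid or an amine.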